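The source may hold more compounds than are shown below. What is called first, only, known or untested is meant among the compounds shown, and "the series" means these compounds.

Among the measured compounds shown here, in a functional assay on U-87MG ATCC cells (Homo sapiens) for cytotoxicity, read by sulforhodamine B assay, with a stated time of 96 h (a higher number here means a weaker inhibitor, a lower number a stronger inhibitor), compound 1 `COc1ccc(NS(=O)(=O)/C=C/c2c(OC)cc(OC)cc2OC)cc1` gives 229 nM, while compound 2 `COc1cc(OC)c(/C=C/S(=O)(=O)Nc2ccc(OC)c(O)c2)c(OC)c1` gives 26 nM, the lower of the two numbers so far. Compound 2 is therefore the stronger inhibitor of this pair. Compound 3 `COc1cc(OC)c(/C=C/S(=O)(=O)Nc2ccc(OC)c(N)c2)c(OC)c1` keeps the core of compound 2 and makes a single swap, amino in place of hydroxy on an aromatic carbon. For the measured compounds named here, only one measured step bears on this place: putting hydroxy in place of hydrogen gave an 8.8-fold lower number from compound 1 to compound 2 (0.94 log units; beyond the scatter), a modest step beyond the scatter. No amino has been measured here, but the swap leaves the counts of hydrogen-bond donors and acceptors unchanged. A much smaller step is therefore expected in this assay, with little reason to favour either direction. The estimate amounts to a 1.3-fold lower number from compound 2 to compound 3 (0.11 log units; within the scatter), which is expected to be a small step. For compound 3 the estimated value is 20 nM, with an expected range from 6 nM to 70 nM.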

Compound 3, half-maximal inhibitory concentration: 9 nM
Estimate against measurement, compound 3: 2.2-fold (0.35 log units) above; the measured number falls inside the stated range.
By their numbers in this assay, from the lowest: compound 3; then compound 2; then compound 1.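

Going from 3-hydroxy-4-methoxyphenyl to 3-amino-4-methoxyphenyl gives a 2.9-fold lower number from compound 2 to compound 3 (0.46 log units; beyond the scatter) in this assay and so shows that this position can tell amino from hydroxy, even though the two groups have the same counts of hydrogen-bond donors and acceptors. Measured against plain hydrogen at the same place, amino gives a 25-fold lower number from compound 1 to compound 3 (1.41 log units; beyond the scatter) and is the largest step seen here so far, which means that hydroxy does not capture the whole gain available at this position. Nothing measured here explains why the two groups differ.

The compounds shown leave open how a methylamino, dimethylamino or acetylamino group would compare with amino at this place. They also leave open whether the gain from amino would hold if an ethoxy group took the place of the methoxy group on the same ring.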